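The source may report more compounds than this note shows. Statements on the series, on what has been measured and on what is new or still open speak of the compounds shown alone.

In a toxicity assay on NIH3T3 cells (Mus musculus) for cytotoxicity, read by resazurin assay (a lower number here means that less compound is needed, a higher number that more compound is needed for the effect), compound 3 `c1ccc(-c2ccc(Cn3cncc3CNc3ccc(-c4cc5ccccc5o4)c(-c4ccccc4)c3)cc2)cc1` gives > 10000 nM, which is a limit of the assay rather than a measured number. This value sits at the limit of > 10000 nM in this assay, at which 2 of the 3 values shown sit. Compound 1 `O=C(OC1CCCCC1)c1ccc(NCc2cncn2Cc2ccc(-c3ccccc3)cc2)cc1-c1ccccc1` also gives only a limit in this assay, > 10000 nM. The step that the two limits leave unreadable from compound 1 to compound 3 is therefore not readable in size. Compound 2 `Cc1cccc(-c2cc(NCc3cncn3Cc3ccc(-c4ccccc4)cc3)ccc2-c2nc3ccccc3s2)c1C` gives > 1000 nM, again a limit, sitting at the limit of > 1000 nM in this assay, at which 1 of the 3 values shown sits. Compound 4 `c1ccc(-c2ccc(Cn3cncc3CNc3ccc(-c4nc5ccccc5s4)c(-c4ccccc4)c3)cc2)cc1` differs from compound 3 by 1,3-benzothiazol-2-yl in place of 1-benzofuran-2-yl on an aromatic carbon. Within the data shown here, no measured step covers this change, so the earlier compounds give no size for it; the values of compound 2 and compound 3 show only that neither group reached a number in this assay. Compound 4 is expected to give 20000 nM, within 5000 nM to 100000 nM, a step that the limit leaves unreadable from compound 3 to compound 4 expected to stay within the scatter.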

Compound 4, half-maximal effective concentration: > 1000 nM
Compound 4: no number, only a limit; the forecaster's own chance of this, stated with the estimate: 75%; the middle value is on the limit's open side.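

In this assay compound 4 gives > 1000 nM, which is a limit, so its steps from compound 1, compound 2 and compound 3 cannot be read. From the compounds shown here alone, the actual concentrations at which these four compounds produce the effect remain open.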